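The source may hold more compounds than are shown below. What is called first, only, known or untested is meant among the compounds shown, and "the series" means these compounds.

For the measured compounds named here, in a physicochemical assay for solubility, with a stated time of 24 h, tested at 30 mg/mL (a lower number here means a less soluble compound, a higher number a more soluble compound), compound 1, `CC(=O)N1CC(CC(=O)NO)(NS(=O)(=O)c2ccc(OCc3cc(C)nc4ccccc34)cc2)C1`, gives 800000 nM, and compound 2, `Cc1cc(COc2ccc(S(=O)(=O)NC3(CC(=O)NO)CN(CCC(F)(F)F)C3)cc2)c2ccccc2n1`, gives 3400000 nM, the higher of the two numbers so far. Compound 3, `Cc1cc(COc2ccc(S(=O)(=O)NC3(CC(=O)NO)CN(C(=O)OC(C)C)C3)cc2)c2ccccc2n1`, keeps the core of compound 2 but carries isopropoxycarbonyl in place of 3,3,3-trifluoropropyl on an amine nitrogen in a ring. Going by the values given here, only one measured step bears on this change: a 4.3-fold higher number from compound 1 to compound 2 (0.63 log units; beyond the scatter), a modest step beyond the scatter, made by putting 3,3,3-trifluoropropyl in place of acetyl on that same nitrogen. Acetyl and isopropoxycarbonyl both contain a carbonyl, whereas 3,3,3-trifluoropropyl does not, so compound 3 is expected to fall closer to compound 1 at 800000 nM than to compound 2. Among the compounds with values here, a single step is thin evidence, and no measured compound yet carries isopropoxycarbonyl, so the range must stay wide. Within the data shown here, the expected change is downward, of about the same size as the one measured step, and is estimated as a 3.8-fold lower number from compound 2 to compound 3 (0.58 log units; beyond the scatter). For compound 3 the estimated value is 900000 nM, with an expected range from 250000 nM to 3000000 nM.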

Compound 3, solubility: 1100000 nM
Estimate against measurement, compound 3: 1.2-fold (0.09 log units) below; measured number inside the range.
By their numbers in this assay, from the lowest: compounds 1 and 3 (each within the scatter of the next); then compound 2.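

On the amine nitrogen of the four-membered ring, isopropoxycarbonyl in place of 3,3,3-trifluoropropyl gives a 3.1-fold lower number from compound 2 to compound 3 (0.49 log units; beyond the scatter) in this assay, a modest step beyond the scatter. This is the first comparison at this position between two groups that each carry a carbonyl: isopropoxy in place of methyl on the carbonyl carbon gives a 1.4-fold higher number from compound 1 to compound 3 (0.14 log units; within the scatter), which lies within the scatter, so compound 1 and compound 3 cannot be told apart here, and only compound 2, the one compound shown without a carbonyl on this nitrogen, stands clearly higher. No measurement shown here accounts for this difference.

Compound 2 differs from the other two both in lacking the carbonyl and in carrying three fluorine atoms, so a plain propyl group on this nitrogen would be needed to tell whether the higher number goes with one feature, the other or both. From the compounds shown here alone, how a group bearing a free amine or a carboxylic acid at this position would read in this assay also stays open.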